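Methyl to bromo on the pyrazolone aryl ring

The compounds below may be only part of what the source reports. "The series", "measured", "known", "first", "only" and "open" are said of these compounds alone.

Measured compounds:
- compound 1 `CC1=NN(c2ccc(C)cc2)C(=O)C12C=CC(=O)C=C2c1cccc(C)c1`: 22500 nM
- compound 2 `CC1=NN(c2ccc(C)cc2)C(=O)C12C=CC(=O)C=C2c1ccc(C)cc1`: 37000 nM
- compound 3 `CC1=NN(c2ccccc2)C(=O)C12C=CC(=O)C=C2c1ccc(C)cc1`: 19300 nM

In a functional assay on A549 cells (Homo sapiens) for antiproliferative activity, read by CCK-8 assay, with a stated time of 72 h (a lower number here means a stronger inhibitor, a higher number a weaker inhibitor), compound 1 gives 22500 nM. Its number sits among the three measured values without separating from either neighbour: compound 3 lies close to it, and compound 2, the furthest of the three, is still within the scatter of it. The two measured steps, a 1.6-fold higher number from compound 1 to compound 2 (0.22 log units; within the scatter) and a 1.9-fold lower number from compound 2 to compound 3 (0.28 log units; within the scatter), both concern the methyl groups and both fall within the scatter, so the three compounds are indistinguishable on these numbers.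

Compound 4 `CC1=NN(c2ccc(Br)cc2)C(=O)C12C=CC(=O)C=C2c1cccc(C)c1` is the next compound, and it differs from compound 1 as follows: bromo in place of methyl on an aromatic carbon. Cut one bond further out, the change reads 4-methylphenyl to 4-bromophenyl. Going by the values given here, no measured step introduces bromo, so nothing among the measured compounds bears directly on this change; the only steps available, which move or remove a methyl, were within the scatter. With no evidence for a larger effect, compound 4 is expected to give a number within the scatter of compound 1, with no step beyond it, a 1.1-fold lower number from compound 1 to compound 4 (0.05 log units; within the scatter).

The estimate for compound 4 is therefore 20000 nM, expected to lie between 8000 nM and 50000 nM.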

Compound 4, half-maximal inhibitory concentration: 45400 nM
The estimate for compound 4 lay 2.3-fold (0.36 log units) below the measured number; the measured number falls inside the stated range.
By their numbers in this assay, from the lowest: compounds 3, 1, 2 and 4 (each within the scatter of the next, the first and the last beyond it).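

Going by these compounds alone, replacing 4-methylphenyl with 4-bromophenyl is the first change here that puts a different atom on this aromatic carbon, rather than moving or removing a methyl, and in this assay it gives a 2.0-fold higher number from compound 1 to compound 4 (0.30 log units; within the scatter). This step is still within the scatter, so on these numbers compound 4 does not separate from compound 1, and the finding that the methyl changes leave the compounds indistinguishable now extends to one exchange of methyl for bromo at this place. Nothing shown here gives any measured property of these compounds that could be set beside this result.

The compounds shown leave open whether bromo at this place would give the same result with 4-methylphenyl instead of 3-methylphenyl on the double-bonded ring carbon, since this exchange is seen in one pair only. They also leave open whether a group of a different kind at this place, such as an amine, a carboxylic acid or a longer alkyl chain, would move the number beyond the scatter of compound 1.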